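The compounds below may be only part of what the source reports. "The series", "measured", "known", "first", "only" and "open" are said of these compounds alone.

Values in an assay on U2OS cells for activation of nuclear factor erythroid 2-related factor 2 (Homo sapiens), read by chemiluminescence, with a stated time of 6 h (on this read-out higher numbers stand for an effect only at larger amounts of compound and lower numbers for an effect already at smaller amounts), for the three measured members of the series:

- compound 1, `COc1cccc(S(=O)(=O)/C=C/c2ccccn2)c1`: 2170 nM
- compound 2, `COc1cccc(S(=O)(=O)/C=C/c2cccnc2)c1`: 6290 nM
- compound 3, `COc1cccc(S(=O)(=O)/C=C/c2ccncc2)c1`: 655 nM

Compound 3 gives the lowest number of the three. Its nearest neighbour is compound 1, with a 3.3-fold lower number from compound 1 to compound 3 (0.52 log units; beyond the scatter); the furthest is compound 2, with a 9.6-fold lower number from compound 2 to compound 3 (0.98 log units; beyond the scatter). Both steps lie beyond the scatter, so compound 3 can be called the most potent of the measured set. The remaining step, a 2.9-fold higher number from compound 1 to compound 2 (0.46 log units; beyond the scatter), is also beyond the scatter, so moving the single ring nitrogen around the six-membered ring shifts the read-out each time by a modest amount.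

The next member is compound 4, `COc1cccc(S(=O)(=O)/C=C/c2cncnc2)c1`. Relative to compound 3 the change is pyrimidin-5-yl in place of pyridin-4-yl on a double-bonded chain carbon bound to a double-bonded chain carbon. Within the data shown here, no measured step adds a second ring nitrogen; the three steps in hand only relocate one nitrogen, and all of them are modest in size. On that basis the step from compound 3 to compound 4 is expected to be modest as well, most likely towards a somewhat higher number, as a 1.7-fold higher number from compound 3 to compound 4 (0.23 log units; within the scatter). Compound 4 is therefore estimated at 1100 nM, with a range from 300 nM to 4000 nM.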

Compound 4, half-maximal effective concentration: 7380 nM
Estimate against measurement, compound 4: 6.7-fold (0.83 log units) below; the measured number lies above the stated range.
By their numbers in this assay, from the lowest: compound 3; then compound 1; then compounds 2 and 4 (each within the scatter of the next).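

In this assay, among these compounds, adding a second ring nitrogen at this double-bonded chain carbon has more effect than any relocation of the single nitrogen: pyrimidin-5-yl in place of pyridin-4-yl gives an 11-fold higher number from compound 3 to compound 4 (1.05 log units; beyond the scatter) and is the largest step so far. The result depends on which ring serves as the reference, since pyrimidin-5-yl in place of pyridin-3-yl gives a 1.2-fold higher number from compound 2 to compound 4 (0.07 log units; within the scatter) and cannot be separated from it, whereas the same change from pyridin-2-yl gives a 3.4-fold higher number from compound 1 to compound 4 (0.53 log units; beyond the scatter) and stays modest. The low number of compound 3 is therefore not retained once the ring carries two nitrogens, and no measurement in hand accounts for these differences.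

Still open, from the compounds shown here alone, is how a plain phenyl ring, or another diazine such as pyrazin-2-yl, would compare with pyridin-4-yl at this position. Going by these compounds, it is also open whether an amine or a carboxylic acid on the ring would keep the number of compound 3 or move it towards that of compound 4.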